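Removing a methyl from an aromatic oxygen

The compounds below may be only part of what the source reports. "The series", "measured", "known", "first", "only" and "open" are said of these compounds alone.

Compound 1, `Cc1cc(O)cc(-c2nn(CC#N)cc2-c2ccnc(-c3ccc(Oc4ccccc4)cc3)c2)c1`, gives 21% in a functional assay on OVCAR-4 cells (Homo sapiens) for cytotoxicity, read by sulforhodamine B assay, with a stated time of 48 h, tested at 1 uM; a lower number here means a stronger effect, a higher number a weaker effect of the compound at the concentration tested. Compound 2, `COc1cc(C)cc(-c2nn(CC#N)cc2-c2ccnc(-c3ccc(N(C)C)cc3)c2)c1`, gives 21% in this assay, level with compound 1 at the digits shown and within the usual scatter. For the measured compounds named here, no single-point step between these two compounds is available, so their values are taken only as they stand. Compound 3, `Cc1cc(O)cc(-c2nn(CC#N)cc2-c2ccnc(-c3ccc(N(C)C)cc3)c2)c1`, has not yet been measured in this assay. It differs from compound 2 in one place: hydrogen in place of methyl on an oxygen on an aromatic ring. The 3-methoxy-5-methylphenyl group thus becomes 3-hydroxy-5-methylphenyl. Compound 1 already carries that hydroxy group and gives 21% in this assay, so no shift beyond the scatter is expected in this assay in either direction. The step expected is no change at the digits printed from compound 2 to compound 3 (within the scatter). Compound 3 is therefore estimated at 21%, within a range from 8% to 36%.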

Compound 3, a percentage reported as activity, at one concentration (the size of the read-out at that concentration, not a potency): 27%
Compound 3: the middle estimate sits 6 percentage points below what was measured, and the stated range covers the measured number.
By their numbers in this assay, from the lowest: compounds 1, 2 and 3 (each within the scatter of the next).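

In this assay, replacing methoxy by hydroxy on the 3-methoxy-5-methylphenyl group gives a number 6 percentage points higher from compound 2 to compound 3 (within the scatter) at this oxygen, so hydrogen and methyl there cannot be told apart in this read-out. For the compounds shown here, with the hydroxy group in both compounds, dimethylamino in place of phenoxy on the aromatic carbon gives a number 6 percentage points higher from compound 1 to compound 3 (within the scatter) and so the two groups cannot be told apart here either, which the unpaired values of the earlier compounds could not show. No measurement is available that bears on the reason for these results.

Going by these compounds, whether an ethyl or a longer alkyl chain on this oxygen would give a number beyond the scatter remains open. The same holds for a cyclic amine such as morpholine in place of dimethylamino, and for how these compounds compare at other concentrations.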